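Changing the aromatic group on the saturated ring carbon

A few compounds are considered here, and "the series" means these few. Any claim that something is new, unique, unknown or untested is made for them only; others in the source may bear on it.

Of the compounds shown here, two have been measured in an assay on HEK293 cells for antagonist activity at transient receptor potential M8 protein (Canis lupus familiaris), read by fluorescence and calcium flux, with a stated time of 5 min; on this read-out lower numbers stand for stronger inhibition and higher numbers for weaker inhibition. Compound 1 `O=C(C(Nc1ccccc1F)c1ccc(C(F)(F)F)cc1)N1CCCC1c1cccc(F)c1` gives 9 nM. Compound 2 `O=C(C(Nc1ccccc1F)c1ccc(C(F)(F)F)cc1)N1CCCC1c1ccncc1`, which carries pyridin-4-yl in place of 3-fluorophenyl on a saturated ring carbon, gives 19 nM; the step is a 2.1-fold higher number from compound 1 to compound 2 (0.32 log units; beyond the scatter). Compound 2 thus stands at the higher of the two numbers, with compound 1 the nearest point.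

Compound 3 `O=C(O)c1ccc(C2CCCN2C(=O)C(Nc2ccccc2F)c2ccc(C(F)(F)F)cc2)cc1` is not yet measured. It differs from compound 2 as follows: 4-carboxyphenyl in place of pyridin-4-yl on a saturated ring carbon. For the measured compounds named here, only one measured step, a 2.1-fold higher number from compound 1 to compound 2 (0.32 log units; beyond the scatter), touches the same position: exchanging one six-membered aromatic ring for another on this carbon moved the number modestly. Going by the values given here, no measured pair shows what a 4-carboxyphenyl group at this position does, so the direction cannot be read from the series. A step of modest size is expected in this assay, with a higher number judged somewhat more likely than a lower one, which gives an expected 2.1-fold higher number from compound 2 to compound 3 (0.32 log units; beyond the scatter). Compound 3 is estimated at 40 nM, within 10 nM to 160 nM.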

Compound 3, half-maximal inhibitory concentration: 66 nM
Compound 3: middle estimate off by 1.7-fold (0.22 log units), on the low side; measured number inside the range.
By their numbers in this assay, from the lowest: compound 1; then compound 2; then compound 3.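

With 4-carboxyphenyl on the saturated ring carbon, this assay shows the weakest inhibition of the three compounds, and a 3.5-fold higher number from compound 2 to compound 3 (0.54 log units; beyond the scatter) and a 7.3-fold higher number from compound 1 to compound 3 (0.87 log units; beyond the scatter) are the two steps that place compound 3 there. Compound 1 and compound 3 both carry a six-membered aromatic ring of carbon only, so a ring of that kind does not by itself keep the number low, and what separates this pair at the position is the group on the ring, not the ring atoms. No accompanying measurement bears on what lies behind this shift, so the series gives the order of the three groups and nothing about its origin.

Open, on these data alone, is which part of 4-carboxyphenyl carries the step: a plain phenyl, a methyl ester or a primary amide in place of the carboxylic acid would separate the ring from the acid. Also open, as far as these compounds go, is whether an aminomethyl group or a longer chain ending in a carboxylic acid on the same ring would stay close to compound 3 or return toward compound 1.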